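Fluoro to hydroxy on the methoxy-bearing series

The compounds below may be only part of what the source reports. "The series", "measured", "known", "first", "only" and "open" are said of these compounds alone.

Measured in a functional assay on NCI-H460 cells (Homo sapiens) for antiproliferative activity, with a stated time of 72 h; on this read-out lower numbers stand for stronger inhibition and higher numbers for weaker inhibition:
- compound 1 `C=C1C=CC(=O)[C@@H]2[C@H](Cc3ccc(F)c(F)c3)CC[C@H]12` gives 511 nM
- compound 2 `C=C1C=CC(=O)[C@@H]2[C@H](Cc3ccc(OC)c(F)c3)CC[C@H]12` gives 2.62 nM

Compound 2 , at 2.62 nM, holds the lower of the two numbers. The next structure is compound 3 `C=C1C=CC(=O)[C@@H]2[C@H](Cc3ccc(OC)c(O)c3)CC[C@H]12`, which carries hydroxy in place of fluoro on an aromatic carbon, ortho to a methoxy group (hydroxy in place of fluoro on an aromatic carbon).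

Going by the values given here, only one measured step bears on this change. It is large and lies beyond the scatter: a 200-fold lower number from compound 1 to compound 2 (2.29 log units; beyond the scatter), with methoxy in place of fluoro on an aromatic carbon. That step replaced the other fluoro of compound 1 , so it gives no direct reading on the fluoro that now leaves. Among the compounds with values here, no measured compound carries hydroxy on this ring. The methoxy group stays in compound 3 , so a change much smaller than that large step is expected, tilted towards a higher number, though the direction is poorly supported. The estimate amounts to a 2.3-fold higher number from compound 2 to compound 3 (0.36 log units; beyond the scatter), an expected modest loss. For compound 3 the estimated value is 6 nM, with an expected range from 1 nM to 40 nM.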

Compound 3, half-maximal inhibitory concentration: 16 nM
Compound 3: the middle estimate sits 2.7-fold (0.43 log units) below what was measured, within the range that was stated.
By their numbers in this assay, from the lowest: compound 2; then compound 3; then compound 1.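

In this assay, going by these compounds alone, this is the first exchange that touches the fluoro of compound 2 itself, and hydroxy in its place gives a 6.1-fold higher number from compound 2 to compound 3 (0.79 log units; beyond the scatter), a modest step beyond the scatter. The position, on an aromatic carbon ortho to a methoxy group, is therefore not indifferent to this exchange, yet the step is much smaller than a 200-fold lower number from compound 1 to compound 2 (2.29 log units; beyond the scatter), the change at the other ring position, so with the methoxy group kept the series loses only part of its standing. Nothing at hand accounts for the loss, and the step stands as an observation on a single pair of compounds.

From the compounds shown here alone, whether the loss follows from hydroxy in particular stays open, since an amine or a chloro at this same position would be needed to show how other groups compare with fluoro and hydroxy. Going by these compounds, it also stays open whether the step keeps its size with another group in place of the methoxy group, such as an ethoxy or a longer chain.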